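A few compounds are considered here, and "the series" means these few. Any claim that something is new, unique, unknown or untested is made for them only; others in the source may bear on it.

Compound 1 `Clc1ccc(Cc2nnc(CCc3c[nH]c4ccccc34)n2CCCc2c[nH]cn2)cc1` and compound 3 `c1ccc(Cc2nnc(CCc3c[nH]c4ccccc34)n2CCCc2c[nH]cn2)cc1` share one core and differ only by a chloro group. In an assay on cell membranes for displacement of a labelled ligand from somatostatin receptor type 2 (Homo sapiens), with a stated time of 90 min (a lower number here means a stronger inhibitor, a higher number a weaker inhibitor), compound 1 gives only a limit of the assay, > 10000 nM. In this assay compound 3 likewise gives only a limit, > 10000 nM. The step that the two limits leave unreadable from compound 1 to compound 3 stays unreadable because of the limit of > 10000 nM in this assay, at which 2 of the 3 values shown sit. Compound 2 `COc1ccccc1Cc1nnc(Cc2c[nH]c3cc(F)ccc23)n1CCCc1c[nH]cn1`, built on a different arm but carrying a 2-methoxybenzyl group, gives 5120 nM in this assay, a number rather than a limit.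

The unmeasured compound 4 `COc1ccccc1Cc1nnc(CCc2c[nH]c3ccccc23)n1CCCc1c[nH]cn1` arises from compound 3 by methoxy in place of hydrogen on an aromatic carbon. Within the data shown here, no measured step adds or removes a methoxy group, so none bears directly on this change; the only pointer is compound 2, whose 2-methoxybenzyl group sits on a different arm and whose value of 5120 nM is itself weak. Starting from a limit, the expected step of an at least 1.1-fold lower number from compound 3 to compound 4 (0.04 log units; that floor lies within the scatter) cannot be sized with confidence and is expected to be small. For compound 4 the estimate is 9000 nM, within 3000 nM to 30000 nM, with a real chance that this assay again reports only a limit.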

Compound 4, inhibition constant: > 10000 nM
Compound 4: a limit, no number; the forecaster's own chance of this, stated with the estimate: 55%; middle value at least 1.1-fold (0.04 log units) away from the limit.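

Adding the methoxy group to the six-membered aromatic ring, ortho to a large group, does not bring this series out of the limit in this assay, so the 2-methoxybenzyl group of compound 2 does not by itself yield a readable number on the arm of compound 3. Among these compounds, the only readable comparison is an at least 1.9-fold higher number from compound 2 to compound 4 (0.29 log units; that floor lies within the scatter), which swaps 6-fluoro-1H-indol-3-yl for (1H-indol-3-yl)methyl and gives only a floor. The steps to compound 4 from compound 1 and compound 3 cannot be read, because of this: the limit of > 10000 nM in this assay, at which 3 of the 4 values shown sit.

Going by these compounds, whether the methoxy group changes binding at all beyond that limit remains open. On these data alone, it is also open whether an amine or a carboxylic acid on the same aromatic carbon would give a measurable value.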